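Hydrogen replaces hydroxymethyl in compound 3

A few compounds are considered here, and "the series" means these few. Any claim that something is new, unique, unknown or untested is made for them only; others in the source may bear on it.

In a functional assay on MCF7 cells (Homo sapiens) for cytotoxicity, read by MTT assay, with a stated time of 24 h (a higher number here means a weaker inhibitor, a lower number a stronger inhibitor), compound 2 `CC[C@H](C)[C@@H](O)C(=O)O[C@@H](C(=O)O[C@@H](C(=O)O[C@@H](C(=O)O[C@@H](C(=O)O[C@H](CO)[C@@H](O)[C@H](O)[C@H](O)CO)[C@@H](C)CC)[C@@H](C)CC)[C@@H](C)CC)[C@@H](C)CC` gives 18300 nM and compound 1 `CC[C@H](C)[C@@H](O)C(=O)O[C@@H](C(=O)O[C@@H](C(=O)O[C@@H](C(=O)O[C@@H](C(=O)OC[C@@H](O)[C@@H](O)CO)[C@@H](C)CC)[C@@H](C)CC)[C@@H](C)CC)[C@@H](C)CC` gives 11100 nM in the same test, which puts the two within the usual scatter of each other. The move to compound 3 `CC[C@H](C)[C@@H](O)C(=O)O[C@@H](C(=O)O[C@@H](C(=O)O[C@@H](C(=O)O[C@@H](C(=O)O[C@H](CO)[C@@H](O)[C@H](O)CO)[C@@H](C)CC)[C@@H](C)CC)[C@@H](C)CC)[C@@H](C)CC` is a single swap hydrogen in place of hydroxymethyl on a saturated chain carbon bound to an oxygen on a saturated carbon and a saturated chain carbon in one place: hydrogen in place of hydroxymethyl on a saturated chain carbon bound to an oxygen on a saturated carbon and a saturated chain carbon. For the measured compounds named here, the one measured step that bears on it is a 1.6-fold higher number from compound 1 to compound 2 (0.22 log units; within the scatter) with 2,3,4,5-tetrahydroxy-1-(hydroxymethyl)pentyl in place of 2,3,4-trihydroxybutyl, and on that evidence no change beyond the scatter is expected in this assay for compound 3. The estimated step is a 1.3-fold lower number from compound 2 to compound 3 (0.12 log units; within the scatter) and no larger. Compound 3 is estimated at 14000 nM with a range from 7500 nM to 26000 nM for repeat measurements.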

Compound 3, half-maximal inhibitory concentration: 19000 nM
Compound 3: middle estimate off by 1.4-fold (0.13 log units), on the low side; the measured number falls inside the stated range.
By their numbers in this assay, from the lowest: compounds 1, 2 and 3 (each within the scatter of the next).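

In this assay, for the compounds shown here, hydrogen in place of hydroxymethyl on this saturated chain carbon gives a 1.0-fold higher number from compound 2 to compound 3 (0.02 log units; within the scatter) and so leaves the read-out within the scatter, which is the first direct look at this swap. The other new comparison, a 1.7-fold higher number from compound 1 to compound 3 (0.23 log units; within the scatter) with 2,3,4-trihydroxy-1-(hydroxymethyl)butyl in place of 2,3,4-trihydroxybutyl, is also within the scatter, so this test does not separate the three hydroxyl-bearing chains shown. Nothing measured here bears on why these swaps leave the number within the scatter.

From the compounds shown here alone, all three compounds carry hydroxyl-bearing chains at this place, so the effect of an amine, a carboxylic acid or a plain hydrocarbon chain there remains open. The shared core is also the same throughout, so what its own parts contribute cannot be told from these compounds.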